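Replacing the Ureido Group with a Benzyl Ester Chain

The source may report more compounds than this note shows. Statements on the series, on what has been measured and on what is new or still open speak of the compounds shown alone.

Three compounds sharing one core were tested in a functional assay on HEL cells (Homo sapiens); on this read-out lower numbers stand for higher toxicity in this test and higher numbers for lower toxicity in this test. Compound 1 `Cc1cn([C@@H]2O[C@H](CO[Si](C)(C)C(C)(C)C)[C@@]3(OS(=O)(=O)C=C3NCCC(=O)OCc3ccccc3)[C@H]2O[Si](C)(C)C(C)(C)C)c(=O)n(C)c1=O` gives 200000 nM. Compound 2 `Cc1cn([C@@H]2O[C@H](CO[Si](C)(C)C(C)(C)C)[C@@]3(OS(=O)(=O)C=C3NC(N)=O)[C@H]2O[Si](C)(C)C(C)(C)C)c(=O)n(C)c1=O` gives 11000 nM, the lowest of the three numbers, with compound 3 nearest. Compound 3 `Cc1cn([C@@H]2O[C@H](CO[Si](C)(C)C(C)(C)C)[C@@]3(OS(=O)(=O)C=C3NCC(=O)C(N)=O)[C@H]2O[Si](C)(C)C(C)(C)C)c(=O)n(C)c1=O` gives 14500 nM. The step of an 18-fold lower number from compound 1 to compound 2 (1.26 log units; beyond the scatter) and the step of a 14-fold lower number from compound 1 to compound 3 (1.14 log units; beyond the scatter) were both large, whereas a 1.3-fold higher number from compound 2 to compound 3 (0.12 log units; within the scatter). Compound 4 `Cc1cn([C@@H]2O[C@H](CO[Si](C)(C)C(C)(C)C)[C@@]3(OS(=O)(=O)C=C3NCC(=O)OCc3ccccc3)[C@H]2O[Si](C)(C)C(C)(C)C)c(=O)n(C)c1=O` is the untested member; relative to compound 2 it carries (benzyloxycarbonyl)methyl in place of carbamoyl on an amine nitrogen. This change runs the first step backwards, so a large rise in this assay is expected. Compound 4 is therefore estimated at 120000 nM, within 30000 nM to 300000 nM, an expected step of an 11-fold higher number from compound 2 to compound 4 (1.04 log units; beyond the scatter). That would place it near compound 1, whose number is 200000 nM.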

Compound 4, half-maximal cytotoxic concentration: > 200000 nM
Compound 4: only a limit was reported (the forecaster's own chance of this, stated with the estimate: 20%); middle value at least 1.6-fold (0.22 log units) from the limit.
By their numbers in this assay, from the lowest: compounds 2 and 3 (each within the scatter of the next); then compound 1.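

Compound 4 in this assay is reported only as a limit: the limit of > 200000 nM in this assay, at which 1 of the 4 values shown sits.

Even so, the (benzyloxycarbonyl)methyl group in place of carbamoyl on the amine nitrogen gives an at least 18-fold higher number from compound 2 to compound 4 (1.25 log units; beyond the scatter), and benzyloxy in place of carbamoyl on a carbonyl carbon gives an at least 13-fold higher number from compound 3 to compound 4 (1.13 log units; beyond the scatter). The second step shows that, with the chain on the nitrogen kept, changing only its end is enough for a large step. Benzyloxycarbonyl in place of (benzyloxycarbonyl)methyl on a saturated chain carbon bound to an amine nitrogen gives a number no lower from compound 1 to compound 4 (the limit leaves the size open), and the size of this step cannot be read.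

The compounds shown leave open whether a carboxylic acid or a methyl ester at that chain end would match the benzyl ester or the carbamoyl end.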